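Replacing the bromophenyl end group: expected cytotoxicity

The compounds below may be only part of what the source reports. "The series", "measured", "known", "first", "only" and "open" are said of these compounds alone.

Measured so far:
compound 1 `O=c1ccn(CCCCCOc2ccc(Br)cc2)c(=O)[nH]1`: 100000 nM
compound 2 `O=c1ccn(CCCCCOc2ccc(-c3ccccc3)cc2)c(=O)[nH]1`: 100000 nM
compound 3 `Cc1cn(CCCCCOc2ccc(Br)cc2)c(=O)[nH]c1=O`: 100000 nM

The three measured compounds were tested in an ADME assay on HEL cells (Homo sapiens) for cytotoxicity, read by microscopy; on this read-out higher numbers stand for lower toxicity in this test and lower numbers for higher toxicity in this test. Compound 1 gives 100000 nM, compound 2 gives 100000 nM and compound 3 gives 100000 nM. On these numbers compound 1 stands level with both of its neighbours: the step of no change at the digits printed from compound 1 to compound 2 (within the scatter) and the step of no change at the digits printed from compound 1 to compound 3 (within the scatter) each leave the read-out where it was, within the scatter.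

Compound 4 `Cc1cccc(OCCCCCn2ccc(=O)[nH]c2=O)c1` has not yet been measured. It differs from compound 1 in one place: 3-methylphenyl in place of 4-bromophenyl on an oxygen on a saturated carbon. Within the data shown here, of the measured steps, the one from compound 1 to compound 2 is the closer relative, since it also exchanges the group at the far end of the chain, and it produced no change. The step from compound 1 to compound 3 touches the core instead, and it also produced no change. Neither step gives a reason to expect movement here, so no step beyond the scatter is expected in this assay. For compound 4 the estimated value is 100000 nM, with a range from 40000 nM to 200000 nM, which corresponds to an expected step of no change at the digits printed from compound 1 to compound 4 (within the scatter).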

Compound 4, minimum cytotoxic concentration: > 100000 nM
Compound 4 was reported as a limit; the forecaster's own chance of this, stated with the estimate: 25%; the middle value lies on the limit itself.
By their numbers in this assay, from the lowest: compounds 1, 2 and 3 (each within the scatter of the next).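

In this assay, compound 4 gives > 100000 nM, which is a limit of the assay and not a number. The earlier steps shown here changed only the bromo group or the core, whereas this one exchanges the whole 4-bromophenyl end group for 3-methylphenyl and gives a number no lower from compound 1 to compound 4 (the limit leaves the size open), so this exchange on an oxygen on a saturated carbon brings no sign of higher toxicity in this test. The size of that step cannot be read, because the reading for compound 4 sits at the limit of the test, and the same limit leaves any ranking of the end groups out of reach: the limit of > 100000 nM in this assay, at which 1 of the 4 values shown sits.

The compounds shown leave open whether an end group carrying an amine or a carboxylic acid, or a longer chain, would bring the read-out to a lower number that could be measured. They also leave open how 3-methylphenyl would behave together with the methyl group that compound 3 carries on the core.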